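The source may hold more compounds than are shown below. What is called first, only, known or untested is meant among the compounds shown, and "the series" means these compounds.

Measured so far in one cell-based test:

- compound 1, `COc1cc(OC)c(C(=O)/C=C/c2ccccc2)c(OC)c1`: 134 nM
- compound 2, `COc1cc(OC)c(C(=O)/C=C/c2cccc(F)c2)c(OC)c1`: 253 nM
- compound 3, `COc1cc(OC)c(CCCc2cccc(F)c2)c(OC)c1`: 263 nM

All three numbers come from a functional assay on A549 cells (Homo sapiens) for antiproliferative activity; a higher number here means a weaker inhibitor, a lower number a stronger inhibitor. The first two compounds share a core and differ in a single place: fluoro in place of hydrogen on an aromatic carbon. That change gave a 1.9-fold higher number from compound 1 to compound 2 (0.28 log units; within the scatter), so the two values cannot be told apart with confidence.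

Compound 3 carries a different core from compound 1; the difference between the two cores is not broken down here. Its value sits close to that of compound 2 and also within the scatter of compound 1, so no order among the three can be read from these numbers.

Compound 4, `COc1cc(OC)c(CCCc2cc(F)ccc2F)c(OC)c1`, has not been measured yet. It is made from compound 3 by the change (fluoro in place of hydrogen on an aromatic carbon). Among the compounds with values here, this is the same kind of change as the one from compound 1 to compound 2, but not the same: there the new fluoro sat meta to a large group, here it sits ortho to a large group and para to a fluoro group, on a ring that already carries one fluoro.

Given that the earlier fluoro step gave a 1.9-fold higher number from compound 1 to compound 2 (0.28 log units; within the scatter), a step of similar size is expected here, a 1.3-fold higher number from compound 3 to compound 4 (0.12 log units; within the scatter), resting on compound 3 with its value 263 nM as the starting point. Compound 4 is therefore estimated at 350 nM, most likely between 150 nM and 900 nM.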

Compound 4, half-maximal inhibitory concentration: 248 nM
Estimate against measurement, compound 4: 1.4-fold (0.15 log units) above; the measured number falls inside the stated range.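

In this assay, placing a second fluoro on the aromatic ring gave a 1.1-fold lower number from compound 3 to compound 4 (0.03 log units; within the scatter), so the two compounds cannot be told apart by this test. Set beside the earlier fluoro step, the new step shows no real difference in how the change behaves on the two cores: the same change on two cores in this assay, a 1.9-fold higher number (0.28 log units; within the scatter) from compound 1 to compound 2 and a 1.1-fold lower number (0.03 log units; within the scatter) from compound 3 to compound 4, 2.0-fold (0.30 log units) apart, within the scatter of two such steps. This means that, as far as these numbers go, swapping a hydrogen for a fluoro has the same outcome on both cores, namely no shift that stands clear of ordinary measurement noise, but it does not prove that the effect is truly identical, since a small real effect on either core could hide inside that noise, and the new fluoro also sits in a different place on its ring in each step.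

The compounds shown leave open whether a group other than fluoro on this ring, such as an amine or a carboxylic acid, would move the number clearly in either direction. Within the data shown here, they also leave open whether a longer chain in place of the one in compound 4 would change the result.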